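Shortening the Hydroxycarbamoyl Chain of Compound 2

A few compounds are considered here, and "the series" means these few. Any claim that something is new, unique, unknown or untested is made for them only; others in the source may bear on it.

Among the compounds with values here, in a functional assay on MCF7 cells (Homo sapiens) for cytotoxicity (a higher number here means a weaker inhibitor, a lower number a stronger inhibitor), compound 2 `Cc1ccc2nc(NC(=O)CCCCCCC(=O)NO)sc2c1` gives 1.6 ug/mL as the only actual number so far. Compound 1 `CS(=O)(=O)c1ccc2nc(NC(=O)CCCCC(=O)NO)sc2c1` shows > 30 ug/mL and this is a limit of the assay, not a number. Compound 3 `Cc1ccc2nc(NC(=O)CCCCC(=O)NO)sc2c1` differs from compound 2 by having hydroxycarbamoyl in place of 2-(hydroxycarbamoyl)ethyl on a saturated chain carbon, four bonds along the chain from a carbonyl carbon and nothing else changes. Within the data shown here, no measured pair shows this change, so the expectation is a judgement. In this assay the estimated step of a 5.0-fold higher number from compound 2 to compound 3 (0.70 log units; beyond the scatter) is expected to be a weakening beyond the usual scatter. Compound 3 is estimated at 8 ug/mL with an expected range of 2 ug/mL to 30 ug/mL in this measurement.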

Compound 3, half-maximal inhibitory concentration: 4.27 ug/mL
Compound 3: middle estimate off by 1.9-fold (0.27 log units), on the high side; the range from low to high includes it.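

In this assay, hydroxycarbamoyl in place of 2-(hydroxycarbamoyl)ethyl gives a 2.7-fold higher number from compound 2 to compound 3 (0.43 log units; beyond the scatter), so the shorter chain costs only a modest amount and still gives a measured number. With that shorter chain held the same, methyl in place of methylsulfonyl on an aromatic carbon gives an at least 7.0-fold lower number from compound 1 to compound 3 (0.84 log units; beyond the scatter), which shows that this group also matters. That step is only a bound, because compound 1 stands at a limit and not at a number: the limit of > 30 ug/mL in this assay, at which 1 of the 3 values shown sits.

Going by these compounds, a chain longer than that of compound 2 remains open. So does an amine or a carboxylic acid in place of the hydroxycarbamoyl end.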